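The source may hold more compounds than are shown below. What is called first, only, known or untested is meant among the compounds shown, and "the series" means these compounds.

Within the data shown here, compound 1 `CCO/C(O)=C1\C(COCCn2cc(C(N)=O)nn2)=NC(C)=C(C(=O)OC)C1c1cccc(Cl)c1Cl` gives 3.16 nM in a functional assay (aorta) with Rattus norvegicus as the target (on this read-out lower numbers stand for stronger inhibition and higher numbers for weaker inhibition), the lowest of the three numbers so far. Compound 2 `CCO/C(O)=C1\C(COCCn2cc(C(N)=O)nn2)=NC(C)=C(C(=O)OC)C1c1ccccc1Cl` gives 20 nM in this assay, and compound 3 `CCO/C(O)=C1\C(COCCN2CC(=O)N=C2N)=NC(C)=C(C(=O)OC)C1c1ccccc1Cl` gives 20 nM. Compound 4 `CCO/C(O)=C1\C(COCCn2nncc2C(N)=O)=NC(C)=C(C(=O)OC)C1c1cccc(Cl)c1Cl` differs from compound 1 only in the arrangement of the same atoms: 5-carbamoyl-1H-1,2,3-triazol-1-yl in place of 4-carbamoyl-1H-1,2,3-triazol-1-yl on a saturated chain carbon, two bonds along the chain from an oxygen on a saturated carbon. Among the measured compounds shown here, no measured step swaps these two positions on the triazole. The nearest guide is the step of no change at the digits printed from compound 2 to compound 3 (within the scatter), where a wholly different ring at the same place on the chain left the number unchanged; the step of a 6.3-fold higher number from compound 1 to compound 2 (0.80 log units; beyond the scatter) concerns the chloro and does not bear on this change. A step within the scatter, a 1.3-fold higher number from compound 1 to compound 4 (0.10 log units; within the scatter), is therefore expected. Compound 4 is estimated at 4 nM, with a range from 1.5 nM to 12 nM.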

Compound 4, half-maximal inhibitory concentration: 15.9 nM
Compound 4: the middle estimate sits 4.0-fold (0.60 log units) below what was measured; the measured number lies above the stated range.
By their numbers in this assay, from the lowest: compound 1; then compounds 4, 2 and 3 (each within the scatter of the next).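

Moving the carbamoyl group on the triazole, with the same atoms and the same counted features, gives a 5.0-fold higher number from compound 1 to compound 4 (0.70 log units; beyond the scatter) in this assay. The end of this chain therefore responds to a change, even though the swap of whole rings gave no change at the digits printed from compound 2 to compound 3 (within the scatter) on the way to a different ring. Nothing measured here explains why the arrangement matters.

On these data alone, it remains open whether the 5-carbamoyl arrangement has the same effect with hydrogen in place of chloro, as in compound 2. As far as these compounds go, it also remains open how a carboxylic acid or an amine in place of the carbamoyl group would read.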